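The compounds below may be only part of what the source reports. "The series", "measured", "known", "first", "only" and "open" are said of these compounds alone.

Compounds measured in a functional assay on cardiac atrium for agonist activity at histamine H2 receptor (Cavia porcellus); a lower number here means a less potent compound, a higher number a more potent compound, by a factor of ten per unit of this negative logarithm:
compound 1, `N=C(NCCCc1c[nH]cn1)NCCC(c1ccc(F)cc1)c1cccnc1`: 8.09
compound 2, `N=C(NCCCc1c[nH]cn1)NCCC(c1ccccc1)c1ccc(F)cc1`: 7.73
compound 3, `N=C(NCCCc1c[nH]cn1)NCCC(c1ccccc1)c1ccc(Cl)c(Cl)c1`: 7.46

Compound 2 gives the second highest of the three numbers. Its nearest neighbour is compound 3, which stands a number 0.27 log units lower from compound 2 to compound 3 (within the scatter); its furthest is compound 1, from which compound 2 stands a number 0.36 log units lower from compound 1 to compound 2 (beyond the scatter).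

Compound 4, `N=C(NCCCc1c[nH]cn1)NCCC(Cc1ccccc1)c1ccc(F)cc1`, differs from compound 2 by one change: benzyl in place of phenyl on a saturated chain carbon bound to an aromatic carbon and a saturated chain carbon. Both measured steps act at the same place. The step from compound 1 to compound 2 swaps one aromatic group for another there and gives a number 0.36 log units lower from compound 1 to compound 2 (beyond the scatter); the step from compound 2 to compound 3 swaps substituents on the ring there and gives a number 0.27 log units lower from compound 2 to compound 3 (within the scatter). Neither step inserts a chain carbon between the ring and the attachment point, so the direction of the change to compound 4 is not directly shown. Given that both known changes at this place were modest and downward, compound 4 is expected to lose a little, a step of a number 0.33 log units lower from compound 2 to compound 4 (beyond the scatter). Compound 4 is therefore estimated at 7.4, with a range from 6.8 to 8 in this assay.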

Compound 4, negative logarithm of the half-maximal effective concentration: 6.17
The estimate for compound 4 lay 1.23 log units above the measured number; measured number below the stated range.
By their numbers in this assay, from the lowest: compound 4; then compounds 3 and 2 (each within the scatter of the next); then compound 1.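

Going by these compounds alone, this position proves far less forgiving than the earlier compounds suggested. In this assay, rings attached directly to the saturated chain carbon had given only small differences, such as a number 0.36 log units lower from compound 1 to compound 2 (beyond the scatter), whereas benzyl in place of phenyl gives a number 1.56 log units lower from compound 2 to compound 4 (beyond the scatter), and benzyl in place of pyridin-3-yl gives a number 1.92 log units lower from compound 1 to compound 4 (beyond the scatter). So the single added carbon of the benzyl group costs far more here than either of the earlier ring changes, though nothing available accounts for the size of this drop.

The compounds shown leave open how a cyclohexyl group, a pyridin-3-ylmethyl group or a longer chain such as 2-phenylethyl would fare at this place. They also leave open whether the loss with benzyl would persist if 3,4-dichlorophenyl replaced the 4-fluorophenyl group on the same carbon.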